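Series notes: the step from compound 2 to compound 4

A few compounds are considered here, and "the series" means these few. Any claim that something is new, unique, unknown or untested is made for them only; others in the source may bear on it.

Three compounds carry numbers in a functional assay on L1210 cells (Mus musculus), with a stated time of 1 days; a higher number here means a more potent compound, by a factor of ten per unit of this negative logarithm, a lower number a less potent compound. Compound 1 `COCCC1=C(N2CC2)C(=O)C(CCOC)=C(N2CC2)C1=O` gives 5.18, compound 2 `CCCC1=C(N2CC2)C(=O)C(CCC)=C(N2CC2)C1=O` gives 4.32, and compound 3 `CC(=O)C1=C(N2CC2)C(=O)C(C)=C(N2CC2)C1=O` gives 3.94. Compound 2 stands second highest of the three: compound 1 sits above it beyond the scatter, compound 3 below it beyond the scatter. Compound 4 `CCCC1=C(N2CC2)C(=O)C(CCOC(N)=O)=C(N2CC2)C1=O` is not yet measured; it differs from compound 2 by carbamoyloxy in place of methyl on a saturated chain carbon, two bonds along the chain from a double-bonded ring carbon. Among the compounds with values here, no step between measured compounds matches this change, so its size is a guess. A moderate rise is expected, since compound 1 with oxygen on both chains gives 5.18. For compound 4 the expected value in this assay is 4.8, with a range from 4.1 to 5.5. The expected step is a number 0.48 log units higher from compound 2 to compound 4 (beyond the scatter).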

Compound 4, logarithm of the reciprocal of the active concentration, log(1/C): 4.9
Compound 4: the middle estimate sits 0.10 log units below what was measured; the range from low to high includes it.
By their numbers in this assay, from the lowest: compound 3; then compound 2; then compounds 4 and 1 (each within the scatter of the next).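

With one propyl chain held fixed, propyl to 2-(carbamoyloxy)ethyl on the other chain gives in this assay as a single change a number 0.58 log units higher from compound 2 to compound 4 (beyond the scatter) at this position alone. Compounds 1 and 3 each differ from compound 2 in more than one place, so neither could isolate one chain. Nothing measured here accounts for the rise.

Still open, going by these compounds, is whether the rise needs the carbamoyloxy group or any oxygen on this chain. A 2-hydroxyethyl or 2-methoxyethyl chain here, set against the propyl chain, would separate the two, and an amine at the chain end would extend the comparison.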